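The source may hold more compounds than are shown below. What is called first, only, known or untested is meant among the compounds shown, and "the series" means these compounds.

Measured compounds:
compound 1, `CC(=O)Nc1cc(-c2cc(F)c(OC[C@@H](N)CC(C)C)cc2F)ccn1`, with 1.3 nM;
compound 2, `CC(=O)Nc1cc(-c2ccc(OC[C@@H](N)CC(C)C)c(Cl)c2)ccn1`, with 0.5 nM;
compound 3, `COC(=O)Nc1cc(-c2ccc(OC[C@@](C)(N)CC(C)C)c(F)c2)ccn1`, with 1.1 nM.

Among these three, compound 2 gives the lowest number, and both compound 1 and compound 3 stand beyond the usual scatter above it. Compound 4, `CC(=O)Nc1cc(-c2ccc(OC[C@@H](N)CC(C)C)c(OC(F)(F)F)c2)ccn1`, has not yet been measured. It differs from compound 2 in one place: trifluoromethoxy in place of chloro on an aromatic carbon. For the measured compounds named here, no measured pair here shows this kind of change, so the data give no direct guide to its size. In an assay on isolated protein for inhibition of AP2-associated protein kinase 1 (Homo sapiens), with a stated time of 3 h, in the presence of a further agent that is not named here (on this read-out lower numbers stand for stronger inhibition and higher numbers for weaker inhibition), the step from the chloro compound to the trifluoromethoxy compound is expected to be small and toward a somewhat higher number, a 3.0-fold higher number from compound 2 to compound 4 (0.48 log units; beyond the scatter), at the edge of the scatter. Compound 4 is therefore expected to give about 1.5 nM, within a range from 0.5 nM to 5 nM.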

Compound 4, half-maximal inhibitory concentration: 0.5 nM
Estimate against measurement, compound 4: 3.0-fold (0.48 log units) above; the measured number falls inside the stated range.
By their numbers in this assay, from the lowest: compounds 2 and 4 (each within the scatter of the next); then compounds 3 and 1 (each within the scatter of the next).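

In this assay, the position ortho to a (2-amino-4-methylpentyl)oxy group accepts trifluoromethoxy in place of chloro, with no change at the digits printed from compound 2 to compound 4 (within the scatter), so the printed number holds when 5 heavy atoms replace 1 there. For the compounds shown here, the earlier compounds held no pair differing only at this place, so this step is the sole direct reading of a change here. No supporting measurement bears on why the two groups read alike.

Open, on these data alone, is how a methoxy group, a nitrile or an amine would read at this position. Also open, as far as these compounds go, is whether trifluoromethoxy in place of chloro would read the same on the core of compound 3.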